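The compounds below may be only part of what the source reports. "The series", "measured", "known", "first", "only" and "open" are said of these compounds alone.

Compound 1 `O=C(CN1CCN(c2nnc(Cc3ccccc3)c3ccccc23)CC1)Nc1ccc(F)c(F)c1` and compound 2 `O=C(CN1CCN(c2nnc(Cc3ccccc3)c3ccccc23)CC1)Nc1cccc(Br)c1` share one core and differ only in the group on the amide-type nitrogen. In a functional assay on A549 cells (Homo sapiens) for cytotoxicity, read by MTT assay, with a stated time of 72 h (a higher number here means a weaker inhibitor, a lower number a stronger inhibitor), compound 1 gives 10100 nM, while compound 2 is reported as "not active" (no number reported). Compound 2 therefore has no number of its own and can only be placed as giving no measured half-maximal inhibitory concentration. Compound 3 `Cc1ccc(NC(=O)CN2CCN(c3nnc(Cc4ccccc4)c4ccccc34)CC2)c(C)c1` keeps the same core, and its change from compound 2 is 2,4-dimethylphenyl in place of 3-bromophenyl on an amide-type nitrogen. No step size can be calculated without a number for compound 2. In this assay only a modest move is expected, from no reported number to, if anything, a weak value close to compound 1 at 10100 nM. A second "not active" report is also quite possible. Compound 3 is estimated at 15000 nM, with an expected range from 6000 nM to 40000 nM.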

Compound 3, half-maximal inhibitory concentration: "not active" (no number reported)
Compound 3: no number reported, and the estimate cannot be compared.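

Among these compounds, compound 2 and compound 3 are both reported as not active in this assay and carry no number, and no step between them can be read. No measured evidence bears on this result. The compounds shown leave open how far compound 1 at 10100 nM stands from compound 2 and compound 3.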